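A few compounds are considered here, and "the series" means these few. Any claim that something is new, unique, unknown or untested is made for them only; others in the source may bear on it.

Working notes on the series. Compound 1 `Cc1ccc(Nc2nc(C)c(C(=O)/C=C/c3ccc(Cl)cc3)s2)cc1` reaches only a limit in a functional assay on BGC-823 cells (Homo sapiens) for cytotoxicity, read by MTT assay (on this read-out higher numbers stand for weaker inhibition and lower numbers for stronger inhibition), returning > 25000 nM. Compound 2 `Cc1ccc(Nc2nc(C)c(C(=O)/C=C/c3ccccc3)s2)cc1` likewise gives only a limit in this assay, > 25000 nM. Among the compounds with values here, compound 3 `COc1cc(/C=C/C(=O)c2sc(Nc3cccc(C)c3)nc2C)cc(OC)c1OC` is the one member resolved to a number in this assay, at 17200 nM. Within the data shown here, the sole single-point step, a step that the two limits leave unreadable from compound 1 to compound 2, cannot be sized, since both ends are limits. Compound 2 therefore stands at the limit of this assay, with one further value also a limit and only compound 3 giving a number.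

Compound 4 `Cc1nc(Nc2ccccc2)sc1C(=O)/C=C/c1ccccc1` differs from compound 2 as follows: hydrogen in place of methyl on an aromatic carbon. Among the measured compounds shown here, no measured step concerns this ring; the one step on record, a step that the two limits leave unreadable from compound 1 to compound 2, is unreadable, so no size or direction can be taken from it. What the series does show is the limit of > 25000 nM in this assay, at which 2 of the 3 values shown sit, which argues for compound 4 staying in the same weak region rather than moving beyond the scatter in this assay. Compound 4 is accordingly expected near 30000 nM in this assay, within 12000 nM to 80000 nM, a step that the limit leaves unreadable from compound 2 to compound 4 that is an estimate only.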

Compound 4, half-maximal inhibitory concentration: 19500 nM
For compound 4 the middle estimate is 1.5-fold (0.19 log units) above the measured one; the range from low to high includes it.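

Within the data shown here, replacing the 4-methylphenyl of compound 2 with the phenyl of compound 4 gives the first step at this position that can be read at all in this assay, an at least 1.2-fold lower number from compound 2 to compound 4 (0.10 log units; that floor lies within the scatter). Compound 2 holds only a limit, so this step has a floor and no size, and the floor alone shows no change beyond the scatter. With hydrogen at this place, compound 4 resolves to a number, yet the series as shown stays in a weak region: the limit of > 25000 nM in this assay, at which 2 of the 4 values shown sit.

As far as these compounds go, whether the true step from the methyl to the hydrogen exceeds the scatter stays open, and the step between the two limits cannot be read. Also open, from the compounds shown here alone, is how an amine or a carboxylic acid at this same place on the aromatic ring would read in this assay.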